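A few compounds are considered here, and "the series" means these few. Any claim that something is new, unique, unknown or untested is made for them only; others in the source may bear on it.

Measured in a functional assay on OVCAR-5 cells (Homo sapiens) for inhibition, read by sulforhodamine B assay, with a stated time of 48 h (on this read-out lower numbers stand for stronger inhibition of growth and higher numbers for weaker inhibition of growth), so far:
compound 1 `Nc1cc(N)c2nc(-c3ccccc3)c(NCc3ccc(Cl)c(Cl)c3)nc2c1` gives 40700 nM
compound 2 `Nc1cc(N)c2nc(-c3ccccc3)c(Sc3ccc(F)cc3)nc2c1` gives 45700 nM
compound 3 `Nc1cc(N)c2nc(-c3ccccc3)c(Oc3ccc(F)cc3)nc2c1` gives 47900 nM

Compound 3 carries the highest of the three numbers, yet its gaps to compound 2 and to compound 1 both lie within the scatter, so no order among the three can be read from these values. Going by the values given here, the one single-point step recorded, a 1.0-fold higher number from compound 2 to compound 3 (0.02 log units; within the scatter), is likewise within the scatter.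

Compound 4 `Nc1cc(N)c2nc(-c3ccccc3)c(NCc3ccc(F)cc3)nc2c1` follows from compound 3 by (4-fluorobenzyl)amino in place of 4-fluorophenoxy on an aromatic carbon. Among the compounds with values here, no measured step covers this exact exchange. Within the data shown here, the only indirect bearing comes from compound 1, whose benzylamino link with a 3,4-dichlorophenyl group sits on the same position and gives a number no different within the scatter from compound 3; as no step between compound 1 and compound 3 has been computed, only the two values themselves are compared. Taken with the flat step from compound 2 to compound 3, the shared core appears to set the growth-inhibiting concentration regardless of the linker used so far. Compound 4 is therefore expected to show no shift beyond the scatter, a 1.1-fold lower number from compound 3 to compound 4 (0.06 log units; within the scatter), with an estimated value of 42000 nM in the range 20000 nM to 90000 nM.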

Compound 4, concentration for total growth inhibition: 7590 nM
The estimate for compound 4 lay 5.5-fold (0.74 log units) above the measured number; measured number outside the range, below it.
By their numbers in this assay, from the lowest: compound 4; then compounds 1, 2 and 3 (each within the scatter of the next).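

In this assay, this position, on an aromatic carbon next to the ring nitrogen and ortho to a phenyl group, proves sensitive to the group it carries: (4-fluorobenzyl)amino gives a clear step down from 4-fluorophenoxy (a 6.3-fold lower number from compound 3 to compound 4 (0.80 log units; beyond the scatter)) and from (4-fluorophenyl)sulfanyl (a 6.0-fold lower number from compound 2 to compound 4 (0.78 log units; beyond the scatter)), whereas the exchange of those two showed nothing beyond the scatter. The amino link alone does not account for the lower number, since compound 1 shares it and still lies within the scatter of compound 2 and compound 3; with that link kept, 4-fluorophenyl in place of 3,4-dichlorophenyl also produces a step (a 5.4-fold lower number from compound 1 to compound 4 (0.73 log units; beyond the scatter)), so the aryl group on the chain counts as well. No measurement bearing on the reason for these steps is available.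

Still open, from the compounds shown here alone, is whether the amine hydrogen of the link is needed, which a (4-fluorobenzyl)methylamino group at this place would address, and whether the chain length matters, which a 2-(4-fluorophenyl)ethylamino group would address. Also open, going by these compounds, is how far the gain rests on the fluorine itself or on the absence of the two chlorines, a question for an unsubstituted benzylamino or a 4-chlorobenzylamino group.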